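Chain-end change from compound 1 to compound 4

This account rests on a few compounds, and the source may have more. Where it says the series, first, only, none or still open, it means among the compounds named here.

Measured compounds:
compound 1, `CC(C)(C)OC(=O)NCCNC(=O)CN1CN(c2ccccc2)C2(CCN(C(=O)c3ccc(C(C)(C)C)cc3)CC2)C1=O`, 10900 nM
compound 2, `CC(C)(C)OC(=O)NCCNC(=O)CN1CN(c2ccccc2)C2(CCN(C(=O)c3ccc(C4CCCCC4)cc3)CC2)C1=O`, 5500 nM
compound 3, `O=C(CN1CN(c2ccccc2)C2(CCN(C(=O)c3ccc(C4CCCCC4)cc3)CC2)C1=O)N1CCN(S(=O)(=O)c2ccccc2)CC1`, 14200 nM

Among the measured compounds shown here, in an assay on HEK293 cells for displacement of a labelled ligand from NPC1-like intracellular cholesterol transporter 1 (Homo sapiens) (on this read-out lower numbers stand for stronger inhibition and higher numbers for weaker inhibition), compound 1 stands second highest of the three numbers; compound 3 sits within the scatter of it, and the only single-point step, a 2.0-fold lower number from compound 1 to compound 2 (0.30 log units; within the scatter), also stays within the scatter. Compound 4, `CC(C)(C)c1ccc(C(=O)N2CCC3(CC2)C(=O)N(CC(=O)NCCCCCO)CN3c2ccccc2)cc1`, differs from compound 1 by 3-hydroxypropyl in place of (tert-butoxycarbonyl)amino on a saturated chain carbon, two bonds along the chain from an amide-type nitrogen. No measured step touches this chain end: the one step shown concerns the aromatic carbon, and compound 3 carries a different tail on a different core arrangement, so its value is merely another weak number. With nothing bearing on the change, the expectation is a step of no size beyond the scatter, a 1.1-fold lower number from compound 1 to compound 4 (0.04 log units; within the scatter). Compound 4 is thus estimated at 10000 nM, within 4000 nM to 25000 nM.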

Compound 4, half-maximal inhibitory concentration: 9400 nM
For compound 4 the middle estimate is 1.1-fold (0.03 log units) above the measured one; the measured number falls inside the stated range.
By their numbers in this assay, from the lowest: compounds 2, 4, 1 and 3 (each within the scatter of the next, the first and the last beyond it).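

In this assay, 3-hydroxypropyl in place of (tert-butoxycarbonyl)amino on this saturated chain carbon gives a 1.2-fold lower number from compound 1 to compound 4 (0.06 log units; within the scatter) and so shows that this chain end accepts a quite different group without a step beyond the scatter. For this pair, the (tert-butoxycarbonyl)amino group is not needed to keep the number at this level. Nothing available explains this result.

From the compounds shown here alone, whether an amine, a carboxylic acid or a longer chain at this chain end would move the number beyond the scatter stays open. Also open, going by these compounds, is whether 3-hydroxypropyl gives the same result with the cyclohexyl group of compound 2 on the aromatic carbon.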